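A few compounds are considered here, and "the series" means these few. Any claim that something is new, unique, unknown or untested is made for them only; others in the source may bear on it.

Working notes on the pyridine thiosemicarbazide series.

Of the compounds shown here, three have been read in a functional assay on A-431 cells (Homo sapiens) for cytotoxicity, read by MTT assay, with a stated time of 72 h, tested at 10 uM; on this read-out lower numbers stand for less inhibition of growth and higher numbers for more inhibition of growth at the one concentration tested. Compound 1 `N/C(=N\NC(=S)N1CCOCC1)c1ccccn1` gives 69.4%. Compound 2 `N/C(=N\NC(=S)N1CCCCC1)c1ccccn1` gives 68.1%; a number 1.3 percentage points lower from compound 1 to compound 2 (within the scatter), the change being (piperidin-1-yl in place of morpholin-4-yl on a thiocarbonyl carbon). Compound 3 `Cc1cccc(/C(N)=N/NC(=S)N2CCOCC2)n1` gives 68.1%; a number 1.3 percentage points lower from compound 1 to compound 3 (within the scatter), and the core of compound 3 differs from that of compound 1 by methyl in place of hydrogen on an aromatic carbon. Compound 4 `Cc1cccc(/C(N)=N/NC(=S)N2CCCCC2)n1` has not yet been measured. It differs from compound 3 by piperidin-1-yl in place of morpholin-4-yl on a thiocarbonyl carbon, the same change as that made from compound 1 to compound 2, at the same place.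

The step to compound 4 is expected to be a number 0.1 percentage points lower from compound 3 to compound 4 (within the scatter), because a number 1.3 percentage points lower from compound 1 to compound 2 (within the scatter) was within the scatter. Compound 4 is accordingly estimated at 68%, between 58% and 78%.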

Compound 4, percent growth inhibition at one concentration: 47.8%
For compound 4 the middle estimate is 20.2 percentage points above the measured one, and the stated range ends above it.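

In this assay, the two changes together give a result that neither gives alone, with a number 20.3 percentage points lower from compound 3 to compound 4 (beyond the scatter) and a number 20.3 percentage points lower from compound 2 to compound 4 (beyond the scatter), so on these compounds their steps do not simply add: the same change on two cores in this assay, a number 1.3 percentage points lower (within the scatter) from compound 1 to compound 2 and a number 20.3 percentage points lower (beyond the scatter) from compound 3 to compound 4, 19 percentage points apart, beyond the scatter of two such steps

The methyl change reads the same way: the same change on two cores in this assay, a number 1.3 percentage points lower (within the scatter) from compound 1 to compound 3 and a number 20.3 percentage points lower (beyond the scatter) from compound 2 to compound 4, 19 percentage points apart, beyond the scatter of two such steps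

This shows that a step measured on one core cannot be assumed to hold on the other in this series, but it rests on four compounds at a single concentration and does not show why the steps differ or how either change would behave on a further core.

On these data alone, it remains open whether an ethyl group or a chlorine atom on the same aromatic carbon would behave as methyl does. As far as these compounds go, it is equally open whether thiomorpholin-4-yl or dimethylamino on the thiocarbonyl carbon would follow piperidin-1-yl.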